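Benzothiophene in place of pyrimidine at the aryl position

The compounds below may be only part of what the source reports. "The series", "measured", "known", "first", "only" and "open" are said of these compounds alone.

Measured in a functional assay on BV-2 cells (Mus musculus) for inhibition, read by ELISA, with a stated time of 16 h; on this read-out lower numbers stand for stronger inhibition and higher numbers for weaker inhibition:
- compound 1 `COc1cccc(-c2cc(C)c(N3CCN(c4ncccn4)CC3)nn2)c1`: 2600 nM
- compound 2 `Cc1cc(-c2ccncc2)nnc1N1CCN(c2ncccn2)CC1`: > 100000 nM, a limit of the assay, not a number.
- compound 3 `Cc1cc(-c2cncnc2)nnc1N1CCN(c2ncccn2)CC1`: > 100000 nM, also a limit.

Compound 3 thus stands at the limit, where (the limit of > 100000 nM in this assay, at which 2 of the 3 values shown sit). The measured steps are an at least 38-fold higher number from compound 1 to compound 2 (1.58 log units; beyond the scatter) and an at least 38-fold higher number from compound 1 to compound 3 (1.58 log units; beyond the scatter); between compound 2 and compound 3, a step that the two limits leave unreadable from compound 2 to compound 3. Compound 4 `Cc1cc(-c2cc3ccccc3s2)nnc1N1CCN(c2ncccn2)CC1` differs from compound 3 by 1-benzothiophen-2-yl in place of pyrimidin-5-yl on an aromatic carbon. The entering group has no ring nitrogen, which sets it apart from the two groups that sat at the limit and nearer to compound 1. The expected change is therefore a lower number, an at least 16-fold lower number from compound 3 to compound 4 (1.22 log units; beyond the scatter), with wide uncertainty. The estimate for compound 4 in this assay is 6000 nM, range 1000 nM to 100000 nM.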

Compound 4, half-maximal inhibitory concentration: 24900 nM
Compound 4: middle estimate off by 4.2-fold (0.62 log units), on the low side; low and high end bracket the measured number.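

At this position, a readable value in this assay is not confined to 3-methoxyphenyl: 1-benzothiophen-2-yl gives an at least 4.0-fold lower number from compound 3 to compound 4 (0.60 log units; beyond the scatter) and an at least 4.0-fold lower number from compound 2 to compound 4 (0.60 log units; beyond the scatter). It still falls short of the original aryl group, with a 9.6-fold higher number from compound 1 to compound 4 (0.98 log units; beyond the scatter). Only the two groups with a ring nitrogen remain at the limit: the limit of > 100000 nM in this assay, at which 2 of the 4 values shown sit.

The step from compound 2 to compound 3 cannot be read, so pyridin-4-yl and pyrimidin-5-yl stay unranked. Also open, on these data alone, is whether plain phenyl or 1-benzofuran-2-yl at this position would give a value nearer to that of compound 1 or of compound 4.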